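The compounds below may be only part of what the source reports. "The series", "measured", "known", "first", "only" and "open" are said of these compounds alone.

Working notes on the series. Compound 1 `CC(C)=CCOc1cccc2ccc(N)nc12` carries a 2-methylprop-1-en-1-yl group on the saturated chain carbon bound to the oxygen on the aromatic ring. In an assay on cells with melanin-concentrating hormone receptor 1 (Homo sapiens) as the target, read by radioligand binding (on this read-out lower numbers stand for stronger inhibition and higher numbers for weaker inhibition), compound 1 returns only a limit, > 2000 nM, a case of the limit of > 2000 nM in this assay, at which 1 of the 2 values shown sits. Compound 2 `CC(C)(C)CCOc1cccc2ccc(N)nc12` has neopentyl at the same place, and in this assay compound 2 gives 201 nM. The change is an at least 9.9-fold lower number from compound 1 to compound 2 (0.99 log units; beyond the scatter). Among the compounds with values here, compound 2 therefore holds the only number in the set so far; the other value is a limit and not a number.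

Compound 3 `Nc1ccc2cccc(OCC3CCCO3)c2n1` is the next compound to be measured. The difference from compound 2 is oxolan-2-yl in place of neopentyl on a saturated chain carbon bound to an oxygen on an aromatic ring. Within the data shown here, only one measured step touches this position, the swap of an unsaturated branched chain for a saturated one, and it was large: an at least 9.9-fold lower number from compound 1 to compound 2 (0.99 log units; beyond the scatter). The present change keeps the saturation but trades a branched carbon chain for a five-membered ring with one oxygen, a different kind of exchange, so that step is only a loose guide.

For compound 3 the expectation is a step of a 2.0-fold higher number from compound 2 to compound 3 (0.30 log units; within the scatter), with no direction asserted beyond the scatter. The estimate for compound 3 is 400 nM, expected between 100 nM and 2000 nM.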

Compound 3, half-maximal inhibitory concentration: > 2000 nM
Compound 3: a limit, no number; the forecaster's own chance of this, stated with the estimate: 15%; middle value at least 5.0-fold (0.69 log units) away from the limit.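

In this assay the exchange of neopentyl for oxolan-2-yl on the saturated chain carbon bound to the oxygen on the aromatic ring gives an at least 9.9-fold higher number from compound 2 to compound 3 (0.99 log units; beyond the scatter), although the heavy-atom count stays the same and the entering group adds one five-membered non-aromatic ring and one hydrogen-bond acceptor. A saturated group at this place is therefore not enough to keep a measurable number: compound 3 is saturated there as well, and compound 2 remains the only one of the three with a number and not a limit. Compound 1 and compound 3 each return a limit, so the step between them cannot be read, and the two share the same ceiling: the limit of > 2000 nM in this assay, at which 2 of the 3 values shown sit.

The one readable change to oxolan-2-yl brings in the ring and its oxygen together and removes the branched carbon chain, so the compounds shown do not separate these features. Also open, as far as these compounds go, is how a cyclopentyl group, a ring of carbon alone, or a 2-methoxyethyl chain, an oxygen without the ring, would read at this place.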